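The source may report more compounds than this note shows. Statements on the series, on what has been measured and on what is new or still open speak of the compounds shown alone.

Three compounds have been measured in an assay on cells for antagonist activity at transient receptor potential cation channel subfamily V member 1 (Homo sapiens), read by FLIPR and calcium flux, with a stated time of 6 min; on this read-out lower numbers stand for stronger inhibition and higher numbers for weaker inhibition:

Compound 1 `CCCCCCSc1nc(C(C)(C)C)ccc1CNC(=O)C(C)c1ccc(NS(C)(=O)=O)c(F)c1` gives 1.5 nM.
Compound 2 `CC(C(=O)NCc1ccc(C(C)(C)C)nc1SCc1ccccc1Cl)c1ccc(NS(C)(=O)=O)c(F)c1` gives 3.8 nM.
Compound 3 `CC(C(=O)NCc1ccc(C(C)(C)C)cc1N1CCN(c2ccccc2)CC1)c1ccc(NS(C)(=O)=O)c(F)c1` gives 0.8 nM.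

Compound 3 shows the lowest number of the three. Its gap to compound 1 lies within the scatter, so the two cannot be ranked against each other; its gap to compound 2 lies beyond the scatter, so compound 3 inhibits more strongly than compound 2.

Compound 4 `CC(C(=O)NCc1ccc(C(C)(C)C)cc1OCc1ccc(F)cc1)c1ccc(NS(C)(=O)=O)c(F)c1` has not yet been measured. It differs from compound 3 in one place: (4-fluorobenzyl)oxy in place of 4-phenylpiperazin-1-yl on an aromatic carbon.

Within the data shown here, no measured step touches this exact change. Among the measured compounds shown here, the only measured step, a 2.5-fold higher number from compound 1 to compound 2 (0.40 log units; beyond the scatter), concerns a different position, where a chain on a sulfur was exchanged for an aryl group, and it weakened inhibition modestly. All three measured compounds, whatever sits in this region of the shared core, remain strong inhibitors. The entering group is smaller than the leaving one and carries fewer acceptors, but nothing measured here says how that matters.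

The expectation is therefore a modest step toward a higher number, a 3.8-fold higher number from compound 3 to compound 4 (0.57 log units; beyond the scatter), with wide uncertainty. Compound 4 is estimated at 3 nM, with a likely range from 0.8 nM to 12 nM.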

Compound 4, inhibition constant: 3.8 nM
For compound 4 the middle estimate is 1.3-fold (0.10 log units) below the measured one; the measured number falls inside the stated range.
By their numbers in this assay, from the lowest: compounds 3 and 1 (each within the scatter of the next); then compounds 2 and 4 (each within the scatter of the next).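

In this assay, putting (4-fluorobenzyl)oxy in place of 4-phenylpiperazin-1-yl on this aromatic carbon gives a 4.8-fold higher number from compound 3 to compound 4 (0.68 log units; beyond the scatter) and so shows that the group held here, ortho to a large group and meta to a tert-butyl group, can change the read-out. Among these compounds, the earlier compounds offered no step at this carbon, and the one step they did offer concerned a group bound to a sulfur. This modest loss still leaves compound 4 at 3.8 nM, so a group joined through oxygen can take the place of the piperazine and keep a low number, although no evidence at hand explains the size or direction of the step.

The change alters several things at once: the linking atom, the non-aromatic ring and the fluorine all differ, so the step cannot be assigned to any one of them. As far as these compounds go, it remains open where a plain benzyloxy group without the fluorine, a piperidin-1-yl group or a simple amine would fall relative to compound 3 and compound 4.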